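The source may hold more compounds than are shown below. What is called first, only, known or untested is meant among the compounds shown, and "the series" means these compounds.

Going by the values given here, compound 1 `COc1ccc(-n2c(SCc3ccc(C)cc3)nnc2-c2cc(OC)c(OC)c(OC)c2)cc1` is the starting point, and its activity has no exact number so far. In a functional assay on HT-29 cells (Homo sapiens) for inhibition, read by MTT assay, with a stated time of 48 h (on this read-out higher numbers stand for weaker inhibition and lower numbers for stronger inhibition), compound 1 reaches only a limit, > 60000 nM. Compound 2 `COc1ccc(-n2c(SCC(=O)c3ccccc3)nnc2-c2cc(OC)c(OC)c(OC)c2)cc1` carries a change on the same saturated chain carbon bound to a sulfur. In this assay compound 2 also reaches only a limit, > 60000 nM.

Compound 3 `COc1ccc(-n2c(SCC(=O)c3ccc(F)cc3)nnc2-c2cc(OC)c(OC)c(OC)c2)cc1` is still unmeasured, and its change from compound 1 lies at that same place: (4-fluorophenyl)carbonyl in place of 4-methylphenyl on a saturated chain carbon bound to a sulfur. Among the compounds with values here, the one measured step that bears on this is a step that the two limits leave unreadable from compound 1 to compound 2, which also brings in a carbonyl-bearing group. Both of its ends are limits, so it has no readable size and shows no direction. The whole measured picture is the limit of > 60000 nM in this assay, at which 2 of the 2 values shown sit. There is therefore no measured support for expecting a step beyond the scatter in either direction, and compound 3 is expected to stay close to that limit, quite possibly without giving a number at all. The estimated change is a number no higher from compound 1 to compound 3 (the limit leaves the size open). For compound 3 the estimated value is 60000 nM, with an expected range from 20000 nM to 120000 nM.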

Compound 3, half-maximal inhibitory concentration: 42500 nM
For compound 3 the middle estimate is 1.4-fold (0.15 log units) above the measured one; the measured number falls inside the stated range.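

In this assay, going by these compounds alone, compound 3 gives 42500 nM, the first exact number for a change on a saturated chain carbon bound to a sulfur. Compound 1 and compound 2 reach only limits. Because those two values are limits, the new steps are floors: there is an at least 1.4-fold lower number from compound 1 to compound 3 (0.14 log units; that floor lies within the scatter), and for the swap of hydrogen for fluoro alone there is an at least 1.4-fold lower number from compound 2 to compound 3 (0.14 log units; that floor lies within the scatter), so the true differences could be larger, but neither floor on its own shows a change beyond the usual scatter. The step between compound 1 and compound 2 still cannot be read, and the series as a whole stays close to the edge of what this read-out can report: the limit of > 60000 nM in this assay, at which 2 of the 3 values shown sit.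

The compounds shown leave open how large the effect of the fluoro really is, since its comparison compound, compound 2, has no exact number. They also leave open whether a different group in place of the fluoro, such as an amine or a carboxylic acid, or a longer chain between the sulfur and the carbonyl, would shift the number in this assay clearly beyond the scatter.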